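The source may hold more compounds than are shown below. What is called first, only, known or untested is meant among the compounds shown, and "the series" means these compounds.

- compound 1 `CC(C)=CC[C@@H](OC[C@H](C)O)C1=CC(=O)c2c(O)ccc(O)c2C1=O`: 40300 nM
- compound 2 `CC(=O)OCCO[C@H](CC=C(C)C)C1=CC(=O)c2c(O)ccc(O)c2C1=O`: 41500 nM
- compound 3 `CC(C)=CC[C@@H](OC(=O)C1CCOC1)C1=CC(=O)c2c(O)ccc(O)c2C1=O`: 73500 nM
- compound 4 `CC(C)=CC[C@@H](OC(=O)C1CCCO1)C1=CC(=O)c2c(O)ccc(O)c2C1=O`: not yet measured

In a functional assay on HeLa cells (Homo sapiens) for cytotoxicity, read by MTT assay (a higher number here means a weaker inhibitor, a lower number a stronger inhibitor), compound 3 gives 73500 nM, a value that cannot be told apart from those of the other two compounds. Compound 4 has the same atoms as compound 3, joined differently: oxolan-2-yl in place of oxolan-3-yl on a carbonyl carbon.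

Among the measured compounds shown here, no measured step makes this exact swap, so the evidence is indirect. The closest is a 1.8-fold higher number from compound 1 to compound 3 (0.26 log units; within the scatter) and a 1.8-fold higher number from compound 2 to compound 3 (0.25 log units; within the scatter), where a different group was exchanged for the (oxolan-3-yl)carbonyl. A third change gave a 1.0-fold higher number from compound 1 to compound 2 (0.01 log units; within the scatter). All three steps stay within the scatter, even though each replaced a whole group, whereas compound 4 only moves the attachment point on the ring. No step beyond the scatter is therefore expected, and no direction can be predicted. The expected change is a 1.1-fold lower number from compound 3 to compound 4 (0.05 log units; within the scatter). The estimate for compound 4 is 65000 nM, with an expected range from 30000 nM to 140000 nM.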

Compound 4, half-maximal inhibitory concentration: 17000 nM
The estimate for compound 4 lay 3.8-fold (0.58 log units) above the measured number; measured number below the stated range.
By their numbers in this assay, from the lowest: compound 4; then compounds 1, 2 and 3 (each within the scatter of the next).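

In this assay, moving the ring's attachment point gives a 4.3-fold lower number from compound 3 to compound 4 (0.64 log units; beyond the scatter) even though the atoms stay the same, so this position responds to how the ring is joined to the carbonyl carbon, not only to which atoms are present. The earlier compounds shown here exchanged whole groups and still stayed within the scatter of each other, whereas the (oxolan-2-yl)carbonyl group separates compound 4 from both of them, with a 2.4-fold lower number from compound 2 to compound 4 (0.39 log units; beyond the scatter) and with a 2.4-fold lower number from compound 1 to compound 4 (0.37 log units; beyond the scatter) as well. Nothing available here gives a measured reason for this difference and so the cause remains unknown.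

Still open, from the compounds shown here alone, is whether this result depends on the ring oxygen or on the ring itself. A pyrrolidin-2-yl ring, an amine, or a plain cyclopentyl ring on the same carbonyl carbon would help to tell these apart.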